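The compounds below may be only part of what the source reports. "The series", "measured", "known", "first", "only" and "open" are said of these compounds alone.

In a functional assay on QGY7701 cells (Homo sapiens) for cytotoxicity, read by MTT assay, with a stated time of 24 h (on this read-out lower numbers stand for stronger inhibition and higher numbers for weaker inhibition), compound 1 `C=CC1=C(C(=O)NCc2ccccc2F)C(c2ccc(F)cc2)OC1` gives 51400 nM. Compound 2 `C=CC1=C(C(=O)NC2CCCCC2)C(c2ccc(OC)cc2)OC1` gives only > 100000 nM, which is a limit of the assay and not a number. It therefore stands at the limit of > 100000 nM in this assay, at which 1 of the 2 values shown sits. Compound 3 `C=CC1=C(C(=O)NC2CCCCC2)C(c2ccc(F)cc2)OC1` differs from compound 2 by fluoro in place of methoxy on an aromatic carbon, which brings its ring into line with that of compound 1. Because compound 2 sits at the limit of > 100000 nM in this assay, at which 1 of the 2 values shown sits, the step to compound 3 is expected to stay near that edge, as an expected step of an at least 1.2-fold lower number from compound 2 to compound 3 (0.09 log units; that floor lies within the scatter) of modest size. Compound 3 is expected to give 80000 nM, within a range from 30000 nM to 200000 nM.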

Compound 3, half-maximal inhibitory concentration: 40500 nM
Estimate against measurement, compound 3: 2.0-fold (0.30 log units) above; the range from low to high includes it.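

In this assay, 4-fluorophenyl in place of 4-methoxyphenyl, with the cyclohexyl amide kept, gives an at least 2.4-fold lower number from compound 2 to compound 3 (0.39 log units; beyond the scatter). That step is only a floor, because compound 2 sits at a limit of the assay and not at a number: the limit of > 100000 nM in this assay, at which 1 of the 3 values shown sits. With 4-fluorophenyl kept, cyclohexyl in place of 2-fluorobenzyl on the amide nitrogen gives a 1.3-fold lower number from compound 1 to compound 3 (0.10 log units; within the scatter), so these two amide groups cannot be told apart here.

The compounds shown leave open how chloro or an amine would read in place of the fluoro. Also open, on these data alone, is whether 4-methoxyphenyl paired with the 2-fluorobenzyl amide would reach the limit too.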